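Butoxy oxime ether in the A-375 series

The source may hold more compounds than are shown below. What is called first, only, known or untested is meant among the compounds shown, and "the series" means these compounds.

In a functional assay on A-375 cells (Homo sapiens) for antiproliferative activity (a lower number here means a stronger inhibitor, a higher number a weaker inhibitor), compound 3 `COCCCO/N=C/c1c(N)ncnc1Oc1ccc2[nH]c(C)cc2c1F` gives 300 nM, the second highest of three numbers; compound 1 `CCO/N=C/c1c(N)ncnc1Oc1ccc2[nH]c(C)cc2c1F` gives 27 nM and compound 2 `CO/N=C/c1c(N)ncnc1Oc1ccc2cccnc2c1` gives 886 nM. Compound 4 `CCCCO/N=C/c1c(N)ncnc1Oc1ccc2[nH]c(C)cc2c1F` differs from compound 3 by methyl in place of methoxy on a saturated chain carbon, three bonds along the chain from an oxygen on an unsaturated carbon. Among the compounds with values here, the only step measured on the same chain is an 11-fold higher number from compound 1 to compound 3 (1.05 log units; beyond the scatter), which added the methoxymethyl; no measured pair removes a methoxy while keeping the chain length, so that step gives direction only loosely. Compound 4 keeps the longer chain of compound 3 but loses its acceptor, so a moderate move back toward compound 1 is expected, a 2.7-fold lower number from compound 3 to compound 4 (0.44 log units; beyond the scatter). The estimate for compound 4 is 110 nM, within 30 nM to 400 nM.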

Compound 4, half-maximal inhibitory concentration: 446 nM
For compound 4 the middle estimate is 4.1-fold (0.61 log units) below the measured one; the measured number lies above the stated range.
By their numbers in this assay, from the lowest: compound 1; then compounds 3, 4 and 2 (each within the scatter of the next, the first and the last beyond it).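

In this assay, replacing 3-methoxypropyl with butyl gives a 1.5-fold higher number from compound 3 to compound 4 (0.17 log units; within the scatter), so the methoxy with its hydrogen-bond acceptor shows no readable contribution at this position. The large step seen with the methoxy-bearing chain also appears without that oxygen, at a 17-fold higher number from compound 1 to compound 4 (1.22 log units; beyond the scatter), so the loss relative to compound 1 does not depend on the methoxy. No available evidence bears on the origin of this loss. Open, on these data alone, is whether a propyl chain falls nearer compound 1 or compound 4, and whether an amine or a carboxylic acid at the chain end would match methoxy and methyl.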